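Same atoms, different ring: compound 2 to compound 3

The compounds below may be only part of what the source reports. "The series", "measured", "known", "first", "only" and "open" are said of these compounds alone.

Among the compounds with values here, in a functional assay (aorta) with Rattus norvegicus as the target (on this read-out higher numbers stand for an effect only at larger amounts of compound and lower numbers for an effect already at smaller amounts), the series holds two measured members so far. Compound 1 `N#Cc1ccc2c(c1)C(N1CCCCC1=O)=CC(CF)(CF)O2` gives 162 nM, and compound 2 `N#Cc1ccc2c(c1)C(n1ccccc1=O)=CC(CF)(CF)O2` gives 24.6 nM, the lower of the two numbers. Next comes compound 3 `N#Cc1ccc2c(c1)C(c1cccc[n+]1[O-])=CC(CF)(CF)O2`, with the change (a group of 7 heavy atoms (5 carbon, 1 nitrogen, 1 oxygen; one six-membered aromatic ring with 1 hetero atom) in place of a group of 7 heavy atoms (5 carbon, 1 nitrogen, 1 oxygen; one six-membered aromatic ring with 1 hetero atom), on a double-bonded ring carbon). The two groups have the same atoms, joined differently, and both sit on a double-bonded ring carbon of the shared core.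

Within the data shown here, only one measured step bears on this: a 6.6-fold lower number from compound 1 to compound 2 (0.82 log units; beyond the scatter). There, a six-membered non-aromatic ring gave way to a six-membered aromatic ring. The new change does not repeat that move, since the group leaving and the group entering are both aromatic. Among the measured compounds shown here, no measured step exchanges one aromatic group for another, so the data offer no direction. For the measured compounds named here, with a 6.6-fold lower number from compound 1 to compound 2 (0.82 log units; beyond the scatter) as the only guide, no shift beyond the usual scatter is expected in this assay, though the uncertainty is wide. The expected step is a 1.1-fold lower number from compound 2 to compound 3 (0.05 log units; within the scatter). Compound 3 is estimated at 22 nM, with an expected range of 6 nM to 80 nM.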

Compound 3, half-maximal effective concentration: 16.6 nM
For compound 3 the middle estimate is 1.3-fold (0.12 log units) above the measured one; the range from low to high includes it.
By their numbers in this assay, from the lowest: compounds 3 and 2 (each within the scatter of the next); then compound 1.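

In this assay, within the data shown here, the first exchange of one aromatic group for another at the double-bonded ring carbon gives a 1.5-fold lower number from compound 2 to compound 3 (0.17 log units; within the scatter), so these two isomeric groups cannot be told apart here, even though the group leaving has 2 hydrogen-bond acceptors and a double bond outside aromatic rings and the group entering has 1 hydrogen-bond acceptor and no such bond. The second aromatic group also stands clear of the non-aromatic ring of compound 1, with a 9.8-fold lower number from compound 1 to compound 3 (0.99 log units; beyond the scatter), so the earlier gap, a 6.6-fold lower number from compound 1 to compound 2 (0.82 log units; beyond the scatter), no longer rests on a single aromatic group, though it still rests on a single non-aromatic comparator. No measurement at hand accounts for either gap.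

As far as these compounds go, whether a phenyl ring or a pyridine ring without the oxygen would stay level with compound 2 and compound 3 or fall back toward compound 1 remains open, and so does the role of the oxygen in these groups. From the compounds shown here alone, all three compounds also share a core bearing two fluoromethyl groups, so whether the gap to the non-aromatic ring persists with two methyl groups on that ring atom is unknown.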